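This account rests on a few compounds, and the source may have more. Where it says the series, first, only, none or still open, it means among the compounds named here.

Of the compounds shown here, three have been measured in an assay on isolated protein for inhibition of DNA topoisomerase 1 (Homo sapiens), tested at 20 uM; a lower number here means a weaker effect, a higher number a stronger effect of the compound at the concentration tested. Compound 1 `O=C(/C=C/c1ccc(N2CCCC2)cc1)c1ccc(O)cc1` gives 60%. Compound 2 `O=C(/C=C/c1ccc(F)cc1)c1ccc(O)cc1O` gives 56.7%. Compound 3 `COc1cc(O)ccc1C(=O)/C=C/c1ccc(F)cc1` gives 61.6%, a number that lies within the usual scatter of both others, with compound 1 the nearer and compound 2 the further of the two.

The next compound, compound 4 `O=C(/C=C/c1ccc(F)cc1)c1ccc(O)cc1`, differs from compound 3 by hydrogen in place of methoxy on an aromatic carbon. For the measured compounds named here, only one measured step touches this region of the shared core: a number 4.9 percentage points higher from compound 2 to compound 3 (within the scatter), which adds a methyl to an oxygen there and stays within the scatter. Where compound 4 carries a hydrogen, a hydroxy is carried by compound 2, which gives 56.7%, a value that is again within the scatter of compound 3. Going by the values given here, nothing measured so far points to a change at this place that rises above the noise of repeated measurements, so the step expected here is a number 3.6 percentage points lower from compound 3 to compound 4 (within the scatter), in no clear direction. Compound 4 is therefore estimated to give 58%, with a likely range from 45% to 70%.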

Compound 4, a percentage reported as inhibition, at one concentration (the size of the read-out at that concentration, not a potency): 18%
Compound 4: the middle estimate sits 40 percentage points above what was measured; measured number below the stated range.
By their numbers in this assay, from the lowest: compound 4; then compounds 2, 1 and 3 (each within the scatter of the next).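

In this assay the aromatic carbon ortho to a large group and meta to a hydroxy group proves sensitive: hydrogen in place of methoxy brings a number 43.6 percentage points lower from compound 3 to compound 4 (beyond the scatter) and hydrogen in place of hydroxy brings a number 38.7 percentage points lower from compound 2 to compound 4 (beyond the scatter) as its result. Methoxy and hydroxy gave values within the scatter of each other, so their earlier comparison could not show that losing the group altogether has a large effect with fluoro elsewhere on the shared core. Compound 1 goes against any general need for a group here, since it also carries hydrogen at this place, and fluoro in place of pyrrolidin-1-yl gives a number 42 percentage points lower from compound 1 to compound 4 (beyond the scatter) as its step.

No available evidence accounts for these drops. From the compounds shown here alone, it remains open whether an ethoxy group or an amine at this carbon would keep the number high, and whether pyrrolidin-1-yl would change the result for compound 3.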